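Benzyloxy to methoxy on the shared core

A few compounds are considered here, and "the series" means these few. Any claim that something is new, unique, unknown or untested is made for them only; others in the source may bear on it.

In a functional assay on MDA-MB-435 cells (Homo sapiens) for cytotoxicity, read by MTT assay, with a stated time of 72 h (a higher number here means a weaker inhibitor, a lower number a stronger inhibitor), compound 1 `C=CC(C)(C/C=C(\C)CCC=C(C)C)c1ccc(OCc2ccccc2)c(OCc2ccccc2)c1` gives "not determined" (no result reported) as its entry, so no number stands for it. Compound 3 `C=CC(C)(C/C=C(\C)CCC=C(C)C)c1ccc(OC(=O)c2ccccc2)c(OC(=O)c2ccccc2)c1` gives "not active" (no number reported) as its entry, again without a number. Among the compounds with values here, compound 2 `C=CC(C)(C/C=C(\C)CCC=C(C)C)c1ccc(O)c(OCc2ccccc2)c1` gives 18.6 ug/mL as the only number, so it has no rank against the other two.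

The next compound is compound 4 `C=CC(C)(C/C=C(\C)CCC=C(C)C)c1ccc(O)c(OC)c1`. Its change from compound 2 is hydrogen in place of phenyl on a saturated chain carbon bound to an oxygen on an aromatic ring in the structure: hydrogen in place of phenyl on a saturated chain carbon bound to an oxygen on an aromatic ring, which also reads as benzyloxy to methoxy.

No measured pair sizes this change, and no direction follows from the data. With compound 2 at 18.6 ug/mL as the sole anchor, the expectation in this assay is no shift beyond the scatter. The estimated step of a 1.2-fold lower number from compound 2 to compound 4 (0.07 log units; within the scatter) is accordingly small. Compound 4 is expected at 16 ug/mL with an estimated range from 6 ug/mL to 40 ug/mL in this series.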

Compound 4, half-maximal inhibitory concentration: > 25 ug/mL
Compound 4: a limit, no number; the forecaster's own chance of this, stated with the estimate: 20%; middle value at least 1.5-fold (0.19 log units) from the limit.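

In this assay, within the data shown here, compound 4 gives > 25 ug/mL, a limit and not a number, and the only limit among the values here: the limit of > 25 ug/mL in this assay, at which 1 of the 4 values shown sits. Hydrogen in place of phenyl at this place gives an at least 1.3-fold higher number from compound 2 to compound 4 (0.12 log units; that floor lies within the scatter), which offers the first directional information on this position, although that floor does not establish a real loss. The methoxy of compound 4 shows no gain over the benzyloxy of compound 2, so the phenyl cannot yet be called dispensable or necessary for the cytotoxicity seen.

As far as these compounds go, the true size of the step stays open, since the number for compound 4 lies somewhere past its limit. Also open, from the compounds shown here alone, is how a longer chain such as ethoxy, or a chain ending in an amine, would read on this oxygen.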